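Replacing the bicyclic group on the amide aryl ring

The source may report more compounds than this note shows. Statements on the series, on what has been measured and on what is new or still open speak of the compounds shown alone.

Compound 3 `Nc1noc2c(N3CC[C@@H](NC(=O)c4ccc(-n5cnc6ncccc65)cc4Cl)C3)ncc(Cl)c12` stands second highest of the three numbers in a physicochemical assay for permeability, using PAMPA, with a stated time of 5 h, tested at 5 uM (a higher number here means that the compound crosses the layer faster, a lower number that the compound crosses the layer more slowly), at 3.1 10^-6 cm/s. Compound 2 `Cc1ncn(-c2ccc(C(=O)N[C@@H]3CCN(c4ncc(Cl)c5c(N)noc45)C3)c(Cl)c2)n1` gives 11.6 10^-6 cm/s and compound 1 `Nc1noc2c(N3CC[C@@H](NC(=O)c4ccc(-n5cnnc5)cc4Cl)C3)ncc(Cl)c12` gives 0.7 10^-6 cm/s. The steps to compound 3 are a 3.7-fold lower number from compound 2 to compound 3 (0.57 log units; beyond the scatter) and a 4.4-fold higher number from compound 1 to compound 3 (0.65 log units; beyond the scatter). Compound 4 `Cn1cc(-c2ccc(C(=O)N[C@@H]3CCN(c4ncc(Cl)c5c(N)noc45)C3)c(Cl)c2)cnc1=O` carries a group of 8 heavy atoms (5 carbon, 2 nitrogen, 1 oxygen; one six-membered aromatic ring with 2 hetero atoms) in place of a group of 9 heavy atoms (6 carbon, 3 nitrogen; one five-membered aromatic ring with 2 hetero atoms, one six-membered aromatic ring with 1 hetero atom), on an aromatic carbon, meta to a chloro group and para to a large group. All three measured steps alter the same place, the third being a 17-fold higher number from compound 1 to compound 2 (1.22 log units; beyond the scatter); none involves the entering group, so its direction rests on the spread alone. A modest step in this assay is expected, more likely downward than upward. Compound 4 is therefore expected to show a 2.1-fold lower number from compound 3 to compound 4 (0.32 log units; beyond the scatter), estimated at 1.5 10^-6 cm/s with a range of 0.4 10^-6 cm/s to 5 10^-6 cm/s.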

Compound 4, apparent permeability: 0.7 10^-6 cm/s
Estimate against measurement, compound 4: 2.1-fold (0.33 log units) above, within the range that was stated.
By their numbers in this assay, from the lowest: compounds 1 and 4 (each within the scatter of the next); then compound 3; then compound 2.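

In this assay, the entering six-membered aromatic ring with 2 hetero atoms gives a 4.4-fold lower number from compound 3 to compound 4 (0.65 log units; beyond the scatter) and a 17-fold lower number from compound 2 to compound 4 (1.22 log units; beyond the scatter), but no change at the digits printed from compound 1 to compound 4 (within the scatter). Group size does not order these numbers: the entering group is larger than the group in compound 2 and smaller than the group in compound 3, yet compound 4 has the lowest number of the three. No measurement available here accounts for these differences.

On these data alone, what a morpholine on this aromatic carbon would give remains open, as does the contribution of the methyl group on the entering ring.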